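Dimethylamino for methyl on a pyridin-4-yl core

A few compounds are considered here, and "the series" means these few. Any claim that something is new, unique, unknown or untested is made for them only; others in the source may bear on it.

The measured compounds:
compound 1, `CN(C)c1cccc(Nc2nccc(-c3ccccn3)n2)c1`, 400 nM;
compound 2, `Cc1cccc(Nc2nccc(-c3ccccn3)n2)c1`, 700 nM;
compound 3, `Cc1cccc(Nc2nccc(-c3ccncc3)n2)c1`, 8800 nM.

All three were tested in a functional assay for inhibition, with Homo sapiens as the target; a lower number here means a stronger inhibitor, a higher number a weaker inhibitor. Compound 2 and compound 1 share one core and differ in a single place: dimethylamino in place of methyl on an aromatic carbon. That change gave a 1.8-fold lower number from compound 2 to compound 1 (0.24 log units; within the scatter), so the two numbers sit within the scatter of one another and no order between them can be read.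

Compound 3 has the core changed instead: pyridin-4-yl in place of pyridin-2-yl on an aromatic carbon. That change gave a 13-fold higher number from compound 2 to compound 3 (1.10 log units; beyond the scatter), a large step, and compound 3 carries the highest number of the three; compound 1 lies a further distance below it than compound 2 does.

Compound 4, `CN(C)c1cccc(Nc2nccc(-c3ccncc3)n2)c1`, has not yet been measured in this assay. It stands to compound 3 as compound 1 stands to compound 2: dimethylamino in place of methyl on an aromatic carbon. The place lines of the two changes read the same word for word, so this is the same change on the other core.

For the measured compounds named here, only one earlier example of this change exists, and on its own core it stayed within the scatter. Going by the values given here, the expectation for compound 4 therefore rests on the single step from compound 2 to compound 1 and on the value of compound 3: compound 4 is expected to show a step of about a 1.8-fold lower number from compound 3 to compound 4 (0.25 log units; within the scatter), small and of uncertain sign, because compound 2 to compound 1 gave a 1.8-fold lower number from compound 2 to compound 1 (0.24 log units; within the scatter). On that basis compound 4 is estimated at 5000 nM in this assay, most likely between 2000 nM and 13000 nM.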

Compound 4, half-maximal inhibitory concentration: 3700 nM
Compound 4: the middle estimate sits 1.4-fold (0.13 log units) above what was measured, within the range that was stated.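

In this assay, dimethylamino in place of methyl carried over to the second core, with a 2.4-fold lower number from compound 3 to compound 4 (0.38 log units; beyond the scatter), and this step agrees with the one seen on the first core: the same change on two cores in this assay, a 1.8-fold lower number (0.24 log units; within the scatter) from compound 2 to compound 1 and a 2.4-fold lower number (0.38 log units; beyond the scatter) from compound 3 to compound 4, 1.4-fold (0.13 log units) apart, within the scatter of two such steps. The change of core behaved the same way on both aromatic substituents, with pyridin-4-yl in place of pyridin-2-yl giving a 9.3-fold higher number from compound 1 to compound 4 (0.97 log units; beyond the scatter), which matches the earlier step: the same change on two cores in this assay, a 13-fold higher number (1.10 log units; beyond the scatter) from compound 2 to compound 3 and a 9.3-fold higher number (0.97 log units; beyond the scatter) from compound 1 to compound 4, 1.4-fold (0.13 log units) apart, within the scatter of two such steps. Together, the four compounds show that the two changes add up consistently in this small set, but they rest on only two cores and a single step in each direction, so they do not show that dimethylamino would give the same step on any other core, and they give no reason for either step.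

The compounds shown hold only methyl and dimethylamino at this place on the aromatic ring, so it stays open how an unsubstituted amine, a carboxylic acid or a longer chain would behave there on either core. As far as these compounds go, it also stays open whether the higher numbers seen with pyridin-4-yl than with pyridin-2-yl would persist with such groups.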